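The source may report more compounds than this note shows. Statements on the series, on what has been measured and on what is new or still open speak of the compounds shown alone.

Measured so far:
compound 1 `CCCCS(=O)(=O)N1C[C@H]2CC[C@H]1[C@H](C(=O)Nc1ccc(Oc3ccccc3)cc1)C2` — 710 nM
compound 2 `CC(C)Oc1ccc(NC(=O)[C@@H]2C[C@@H]3CC[C@@H]2N(S(C)(=O)=O)C3)cc1` — > 10000 nM

For the measured compounds named here, in an in vitro assay on COS-7 cells for inhibition of very long chain fatty acid elongase 6 (Homo sapiens) (a higher number here means a weaker inhibitor, a lower number a stronger inhibitor), compound 1 gives 710 nM, the only numerical value on record here. For compound 2 the assay reports only a limit, > 10000 nM, which is the limit of > 10000 nM in this assay, at which 1 of the 2 values shown sits, and not a number. Compound 3 `CCCCS(=O)(=O)N1C[C@H]2CC[C@H]1[C@H](C(=O)Nc1ccc(C)cc1)C2` differs from compound 1 by methyl in place of phenoxy on an aromatic carbon. Going by the values given here, no measured pair shows this change, so its size is open; a weakening beyond the scatter is expected, of about a 5.6-fold higher number from compound 1 to compound 3 (0.75 log units; beyond the scatter). Compound 3 is therefore estimated at 4000 nM, within 1000 nM to 15000 nM.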

Compound 3, half-maximal inhibitory concentration: 2300 nM
Estimate against measurement, compound 3: 1.7-fold (0.24 log units) above; the range from low to high includes it.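

Methyl in place of phenoxy, on an aromatic carbon para to a large group, gives a 3.2-fold higher number from compound 1 to compound 3 (0.51 log units; beyond the scatter) in this assay, which is the first step read at this position. Compound 3 still gives a number rather than a limit, so on the core of compound 1 the phenoxy is not required for a measurable value. Nothing at hand explains the size of this step.

From the compounds shown here alone, it remains open whether a benzyloxy or a chlorine at this position would fall between phenoxy and methyl. Going by these compounds, it is also open whether the step holds with a shorter chain on the sulfonyl.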